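This account rests on a few compounds, and the source may have more. Where it says the series, first, only, none or still open, it means among the compounds named here.

Measured compounds, with the result in a functional assay on NCI-H460 cells (Homo sapiens) for antiproliferative activity, read by sulforhodamine B assay, with a stated time of 72 h; on this read-out lower numbers stand for stronger inhibition and higher numbers for weaker inhibition:

compound 1, `Cc1ccc(C(/C=C/c2ccc(F)cc2)=N\Nc2nncc3ccccc23)cc1`, giving 7 nM
compound 2, `Cc1cc(NS(=O)(=O)c2ccc(Nc3nncc4ccccc34)cc2)no1`, giving 28 nM

Within the data shown here, of these two numbers the one for compound 2 is the higher, and the gap to compound 1 lies beyond the usual scatter; no single-point step connects the two structures, so only the two values themselves can be compared.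

Compound 3, `Cc1cc(C)nc(NS(=O)(=O)c2ccc(Nc3nncc4ccccc34)cc2)n1`, is not yet measured in this assay. Relative to compound 2 the change is 4,6-dimethylpyrimidin-2-yl in place of 5-methyl-1,2-oxazol-3-yl on a sulfonamide nitrogen, and the rest of the molecule is kept. Among the measured compounds shown here, no measured step covers a change of this kind, so nothing in the data points firmly in either direction. The working expectation is a step from compound 2 that stays within the scatter, a 1.1-fold higher number from compound 2 to compound 3 (0.03 log units; within the scatter), with no change beyond it. Compound 3 is therefore estimated at 30 nM, with a range from 12 nM to 75 nM.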

Compound 3, half-maximal inhibitory concentration: 0.8 nM
For compound 3 the middle estimate is 38-fold (1.57 log units) above the measured one; measured number below the stated range.
By their numbers in this assay, from the lowest: compound 3; then compound 1; then compound 2.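

In this assay, among these compounds, the group on a sulfonamide nitrogen has a large effect on the number: 4,6-dimethylpyrimidin-2-yl in place of 5-methyl-1,2-oxazol-3-yl gives a 35-fold lower number from compound 2 to compound 3 (1.54 log units; beyond the scatter) and is the only single-place step so far. This position therefore does not treat the two aromatic rings as interchangeable, although each carries 2 hetero atoms and the two groups have the same hydrogen-bond donor and acceptor counts. No supporting measurement accounts for the size of this step.

As far as these compounds go, it remains open whether the step belongs to the six-membered ring or to its two methyl groups; a plain pyrimidin-2-yl on the same nitrogen would separate the two. From the compounds shown here alone, it is equally open how a phenyl group or a 4-methylpyrimidin-2-yl group would read at this position.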